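Methyl on the ring nitrogen: outlook for compound 4

The source may hold more compounds than are shown below. What is called first, only, known or untested is meant among the compounds shown, and "the series" means these compounds.

Measured so far in a functional assay on PC-3 cells (Homo sapiens) for cytotoxicity, read by MTT assay, with a stated time of 72 h; a lower number here means a stronger inhibitor, a higher number a weaker inhibitor:
compound 1 `Cc1ccc(-n2nc(C(=O)Nc3ccc(Oc4ncnc5[nH]ccc45)cc3)c(C)cc2=O)cc1` gives 9610 nM
compound 2 `Cc1cc(=O)n(-c2ccccc2OC(F)(F)F)nc1C(=O)Nc1ccc(Oc2ncnc3[nH]ccc23)cc1` gives 22500 nM
compound 3 `Cc1cc(=O)n(-c2ccccc2OC(F)(F)F)nc1C(=O)Nc1ccc(Oc2ncnc3[nH]ccc23)c(F)c1` gives > 60000 nM, which is a limit of the assay and not a number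

Compound 2 holds the highest of the two numbers shown; its nearest neighbour is compound 1, and the step of a 2.3-fold higher number from compound 1 to compound 2 (0.37 log units; beyond the scatter) lies beyond the scatter. The value for compound 3 is a limit (the limit of > 60000 nM in this assay, at which 1 of the 3 values shown sits). The step of an at least 2.6-fold higher number from compound 2 to compound 3 (0.42 log units; beyond the scatter) is therefore only bounded from one side.

Compound 4 `Cc1cc(=O)n(-c2ccccc2OC(F)(F)F)nc1C(=O)Nc1ccc(Oc2ncnc3c2ccn3C)cc1` differs from compound 2 by methyl in place of hydrogen on an aromatic nitrogen, on an aromatic nitrogen of a five-membered aromatic ring with 1 nitrogen, part of a fused or bridged system of two rings. Neither measured step touches this site: the step from compound 1 to compound 2 exchanged the group on the other aromatic nitrogen, and the step from compound 2 to compound 3 added a fluoro on an aromatic carbon. Both measured steps raised the number, and nothing in the series points the other way. A rise beyond the scatter is expected for compound 4, with a real chance that this assay returns only a limit.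

For compound 4 the expected step is a 2.2-fold higher number from compound 2 to compound 4 (0.35 log units; beyond the scatter). The estimate for compound 4 in this assay is 50000 nM, with a range from 20000 nM to 150000 nM.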

Compound 4, half-maximal inhibitory concentration: 5160 nM
For compound 4 the middle estimate is 9.7-fold (0.99 log units) above the measured one, and the stated range ends above it.
By their numbers in this assay, from the lowest: compounds 4 and 1 (each within the scatter of the next); then compound 2. At a limit, above all of these: compound 3.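

In this assay the series now holds a step in the downward direction at a new site: methyl in place of hydrogen on an aromatic nitrogen of the five-membered aromatic ring gives a 4.4-fold lower number from compound 2 to compound 4 (0.64 log units; beyond the scatter) and is the first change shown to lower the number. Both earlier steps raised it, so the direction of change in this series is not the same at every site, and the hydrogen on this nitrogen is shown not to be needed for a measurable number in this assay, at least with 2-(trifluoromethoxy)phenyl on the other aromatic nitrogen. Nothing measured on these compounds accounts for the step, which stands as an observation only.

Going by these compounds, whether the drop belongs to methyl itself or to any group on this nitrogen stays open: ethyl, a longer chain, or a chain ending in an amine or a carboxylic acid at the same place would separate the two. Equally open, on these data alone, is whether the same methyl lowers the number with 4-methylphenyl on the other aromatic nitrogen, or with the fluoro of compound 3 present.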